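One Methyl Carbon, Two Configurations

The compounds below may be only part of what the source reports. "The series", "measured", "known", "first", "only" and "open" are said of these compounds alone.

In a functional assay (mast cells) for inhibition, with Rattus norvegicus as the target (a higher number here means that more compound is needed for the effect, a lower number that less compound is needed), compound 2 `C[C@@H]1CC/C(=N\Nc2ccc(O)cc2)c2ncc(C(=O)O)c(=O)n21` gives 15600 nM, the higher of the two numbers, and compound 1 `CC1CC/C(=N\Nc2ccc(O)cc2)c2ncc(C(=O)O)c(=O)n21` gives 1300 nM. Among the compounds with values here, the only measured step, a 12-fold higher number from compound 1 to compound 2 (1.08 log units; beyond the scatter), is large and comes with the fact that one of compounds 1 and 2 is drawn with a defined configuration and the other without, at the place where they differ. Compound 3 `C[C@H]1CC/C(=N\Nc2ccc(O)cc2)c2ncc(C(=O)O)c(=O)n21` alters one feature: the two compounds have the same atoms and bonds and differ only in configuration as drawn: 1 of 2 stereo elements differ; a stereocentre at a saturated ring carbon is drawn R in compound 2 and S in compound 3. If compound 1 is a mixture of both configurations, its 1300 nM must come mostly from the S form, so a large drop of similar size is expected, a 22-fold lower number from compound 2 to compound 3 (1.35 log units; beyond the scatter). Compound 3 is estimated at 700 nM, within an expected range of 300 nM to 1600 nM.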

Compound 3, half-maximal effective concentration: 26200 nM
Compound 3: the middle estimate sits 37-fold (1.57 log units) below what was measured, and the stated range ends below it.
By their numbers in this assay, from the lowest: compound 1; then compounds 2 and 3 (each within the scatter of the next).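

In this assay, swapping R for S at the saturated ring carbon gives no change that can be told from noise, with a 1.7-fold higher number from compound 2 to compound 3 (0.23 log units; within the scatter). The S form also stands well apart from the undefined drawing, with a 20-fold higher number from compound 1 to compound 3 (1.30 log units; beyond the scatter). Neither drawn configuration therefore accounts for the lower number of compound 1, which the earlier pair alone could not show.

From the compounds shown here alone, what sets compound 1 apart from both drawn forms stays open. So does whether a hydrogen or an ethyl group in place of the methyl at this ring carbon would shift the number.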